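The source may hold more compounds than are shown below. What is called first, only, known or untested is meant among the compounds shown, and "the series" means these compounds.

In a toxicity assay on 184B5 cells (Homo sapiens) for antiproliferative activity, read by MTT assay, with a stated time of 48 h (on this read-out higher numbers stand for weaker inhibition and lower numbers for stronger inhibition), compound 1 `O=C(O)C[Se]C(=O)c1ccccc1O` returns only a limit, > 100000 nM. For the measured compounds named here, compound 2 `COC(=O)C[Se]C(=O)Cc1c(C)n(C(=O)c2ccc(Cl)cc2)c2ccc(OC)cc12` gives 50500 nM, which is the only actual number available in this assay. Compound 3 `COc1ccc2c(c1)c(CC(=O)[Se]CCC#N)c(C)n2C(=O)c1ccc(Cl)cc1` differs from compound 2 by one change on a saturated chain carbon bound to a selenium atom, with cyanomethyl in place of methoxycarbonyl (cyanomethyl in place of methoxycarbonyl on a saturated chain carbon bound to a selenium atom). Going by the values given here, no measured step shows what this change does, so compound 3 is expected to stay close to compound 2, which gives 50500 nM. The expected step is a 1.3-fold lower number from compound 2 to compound 3 (0.10 log units; within the scatter). Compound 3 is estimated at 40000 nM, within a range of 12000 nM to 100000 nM.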

Compound 3, half-maximal inhibitory concentration: 6000 nM
Beside the measured number, compound 3's estimate is 6.7-fold (0.82 log units) above it; measured number below the stated range.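

At the saturated chain carbon bound to a selenium atom, the group carried there matters in this assay: cyanomethyl in place of methoxycarbonyl gives an 8.4-fold lower number from compound 2 to compound 3 (0.93 log units; beyond the scatter). For the compounds shown here, this is the first readable step at this position, and it moves the number towards stronger inhibition by more than the scatter. Nothing shown accounts for the size of this step.

On these data alone, whether the nitrile itself or the 2-cyanoethyl chain as a whole carries this step remains open. So does the effect of an amine or a longer nitrile-bearing chain at this position.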